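Dichlorophenyl to chlorophenyl amide in the cytotoxic series

The source may report more compounds than this note shows. Statements on the series, on what has been measured and on what is new or still open speak of the compounds shown alone.

Among the measured compounds shown here, compound 2 `O=C(/C=C/C(=O)N1C/C(=C\c2ccc([N+](=O)[O-])cc2)C(=O)/C(=C/c2ccc([N+](=O)[O-])cc2)C1)Nc1ccc(Cl)c(Cl)c1` holds the lowest of the two numbers known so far: in a functional assay on L1210 cells (Mus musculus) for cytotoxicity (a higher number here means a weaker inhibitor, a lower number a stronger inhibitor), compound 2 gives 1700 nM, whereas compound 1 `Cc1cccc(C)c1NC(=O)/C=C/C(=O)N1C/C(=C\c2ccccc2)C(=O)/C(=C/c2ccccc2)C1` gives 22000 nM, a gap beyond the scatter. These two differ in more than one place, so only their values are set side by side. Compound 3 `O=C(/C=C/C(=O)N1C/C(=C\c2ccc([N+](=O)[O-])cc2)C(=O)/C(=C/c2ccc([N+](=O)[O-])cc2)C1)Nc1ccc(Cl)cc1` is not yet measured; it differs from compound 2 by hydrogen in place of chloro on an aromatic carbon. For the measured compounds named here, no measured pair covers this change; a small weakening, or none beyond the scatter, is expected. For compound 3 in this assay the expected value is 2600 nM, between 1000 nM and 6500 nM. That expectation amounts to a step of a 1.5-fold higher number from compound 2 to compound 3 (0.18 log units; within the scatter).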

Compound 3, half-maximal inhibitory concentration: 3600 nM
Beside the measured number, compound 3's estimate is 1.4-fold (0.14 log units) below it; low and high end bracket the measured number.
By their numbers in this assay, from the lowest: compound 2; then compound 3; then compound 1.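

Among the compounds shown here, this is the first pair that differs in one place: in this assay, going from 3,4-dichlorophenyl to 4-chlorophenyl gives a 2.1-fold higher number from compound 2 to compound 3 (0.33 log units; beyond the scatter), a modest step. The chloro on this aromatic carbon, ortho to the remaining chloro group, therefore makes a small but readable difference with the rest of compound 2 unchanged. Nothing available bears on what lies behind this step.

As far as these compounds go, whether a methoxy or an amino group on that carbon would match chloro or hydrogen remains open. So does whether removing the other chloro would give a similar step.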